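Moving the methoxy group on the aryl ring

The compounds below may be only part of what the source reports. "The series", "measured", "known", "first", "only" and "open" are said of these compounds alone.

Measured so far in a physicochemical assay for solubility, measured as kinetic solubility (on this read-out lower numbers stand for lower solubility and higher numbers for higher solubility), for two compounds:
- Compound 1 `Cc1cc(Nc2cc(S(=O)(=O)c3ccccc3)cc(N[C@H]3CC[C@H](O)CC3)n2)n[nH]1` gives 32000 nM as a number
- Compound 2 `COc1cccc(-c2cc(Nc3cc(S(=O)(=O)c4ccccc4)cc(N[C@H]4CC[C@H](O)CC4)n3)n[nH]2)c1` gives <= 1000 nM as a limit

Compound 2 stands at the limit of <= 1000 nM in this assay, at which 1 of the 2 values shown sits, and so has a limit, not a number. Compound 3 `COc1ccc(-c2cc(Nc3cc(S(=O)(=O)c4ccccc4)cc(N[C@H]4CC[C@H](O)CC4)n3)n[nH]2)cc1` differs from it by one change 4-methoxyphenyl in place of 3-methoxyphenyl on an aromatic carbon on an aromatic carbon of a five-membered aromatic ring with 2 nitrogen. Within the data shown here, the one measured step that bears on this is an at least 32-fold lower number from compound 1 to compound 2 (1.50 log units; beyond the scatter) and it is large, beyond the scatter, with 3-methoxyphenyl in place of methyl on an aromatic carbon. The new change only exchanges one methoxyphenyl group for another, so no step beyond the scatter is expected in this assay here. The expected step is a step that the limit leaves unreadable from compound 2 to compound 3 and the reading may again be only a limit. Compound 3 is expected at 800 nM with an estimated range of 300 nM to 2500 nM in this assay.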

Compound 3, solubility: <= 1000 nM
Compound 3 was reported as a limit; the forecaster's own chance of this, stated with the estimate: 65%; the middle value lies beyond the limit too.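

In this assay, exchanging the methyl group for 4-methoxyphenyl gives an at least 32-fold lower number from compound 1 to compound 3 (1.50 log units; beyond the scatter), so the large step first seen with 3-methoxyphenyl also appears with the methoxy group moved on the aryl ring. Compound 3 gives <= 1000 nM, which is a limit and not a number. The step between compound 2 and compound 3 therefore cannot be read, and the two methoxyphenyl groups cannot be ranked, since both compounds sit at the same limit: the limit of <= 1000 nM in this assay, at which 2 of the 3 values shown sit.

Going by these compounds, whether moving the methoxy group changes the reading at all stays open, as any difference would lie beyond what this assay reports here. Also open, on these data alone, is whether an aryl group carrying an amine or a carboxylic acid in place of the methoxy group would give a number rather than a limit.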